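Pyridin-2-yl in place of pyridazin-3-yl on the ring amine

The compounds below may be only part of what the source reports. "The series", "measured", "known", "first", "only" and "open" are said of these compounds alone.

Of the compounds shown here, two have numbers so far in a physicochemical assay for lipophilicity, read by HPLC, measured as chromatographic lipophilicity, at pH 7.4; on this read-out lower numbers stand for lower lipophilicity and higher numbers for higher lipophilicity. Compound 1 `O=C(c1cscn1)N1CCC(C(=O)N2N=CC[C@H]2c2ccccc2)CC1` gives 3, and compound 2 `O=C(C1CCN(c2cccnn2)CC1)N1N=CC[C@H]1c1ccccc1` gives 3.4, the higher of the two. Compound 3 `O=C(C1CCN(c2ccccn2)CC1)N1N=CC[C@H]1c1ccccc1` keeps the core of compound 2 and carries pyridin-2-yl in place of pyridazin-3-yl on an amine nitrogen in a ring. Among the measured compounds shown here, one measured step bears on this change, made on the same amine nitrogen: a number 0.40 log units higher from compound 1 to compound 2 (beyond the scatter). That step is modest and exchanges a different pair of groups, so it offers only a rough guide to size. In this assay an upward move somewhat larger than that step is expected, and the estimated step is a number 0.60 log units higher from compound 2 to compound 3 (beyond the scatter). For compound 3 the expected value is 4, with an estimated range from 3.5 to 4.5.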

Compound 3, distribution coefficient: 5.1
Compound 3: the middle estimate sits 1.10 log units below what was measured; the measured number lies above the stated range.
By their numbers in this assay, from the lowest: compound 1; then compound 2; then compound 3.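

On the amine nitrogen in a ring, the swap from pyridazin-3-yl to pyridin-2-yl gives in this assay a large move: a number 1.70 log units higher from compound 2 to compound 3 (beyond the scatter) and not a small adjustment. Both groups have the same count of heavy atoms and each is one six-membered aromatic ring, so a change of one ring nitrogen to carbon is enough to move the read-out this far at this position. Compared with the (1,3-thiazol-4-yl)carbonyl group on the same nitrogen, pyridin-2-yl gives a number 2.10 log units higher from compound 1 to compound 3 (beyond the scatter) and widens the span of the series; nothing measured here accounts for the size of either step.

On these data alone, whether a phenyl ring on this nitrogen would extend the rise remains open. So does whether a pyridin-2-yl bearing an amine or a carboxylic acid would bring the number back down.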